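The source may report more compounds than this note shows. Statements on the series, on what has been measured and on what is new or still open speak of the compounds shown alone.

Compound 1 `O=C(NO)c1ccc(-c2cn([C@@H]3C[C@H](C(=O)O)N(CCCc4ccccc4)C3)nn2)cc1` reaches only a limit in an assay on Sf9 cells for inhibition of histone deacetylase 11 (Homo sapiens), read by fluorescence, tested at 0.5 uM (on this read-out lower numbers stand for less inhibition and higher numbers for more inhibition at the one concentration tested (going by the name of the read-out)), reported as < 10%. Compound 2 `O=C(NO)c1cccc(-c2cn([C@@H]3C[C@@H](C(=O)O)N(CCCc4ccccc4)C3)nn2)c1` likewise stands at a limit in this assay, reported as < 10%. Both readings rest on (the limit of < 10% in this assay, at which 2 of the 2 values shown sit), so neither compound yields a number to rank. Compound 3 `O=C(NO)c1ccc(-c2cn([C@@H]3C[C@@H](C(=O)O)N(CCCc4ccccc4)C3)nn2)cc1` differs from compound 2 by 4-(hydroxycarbamoyl)phenyl in place of 3-(hydroxycarbamoyl)phenyl on an aromatic carbon. Among the compounds with values here, no measured pair isolates this change, so the step has no anchor; the expectation is for no step beyond the scatter, with compound 3 staying at the limit. Compound 3 is estimated at 5% (range 0% to 15%), an expected step that the limit leaves unreadable from compound 2 to compound 3.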

Compound 3, a percentage reported as inhibition, at one concentration (the size of the read-out at that concentration, not a potency): 14%
Compound 3: middle estimate off by 9 percentage points, on the low side, within the range that was stated.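

In this assay compound 3 gives 14%, the only reading shown that is a number and not a limit. At this position, 4-(hydroxycarbamoyl)phenyl in place of 3-(hydroxycarbamoyl)phenyl gives a number at least 4 percentage points higher from compound 2 to compound 3 (that floor lies within the scatter), while the stereocentre at a saturated ring carbon, drawn S in place of R, gives a number at least 4 percentage points higher from compound 1 to compound 3 (that floor lies within the scatter). Neither step can be sized further: the limit of < 10% in this assay, at which 2 of the 3 values shown sit.

Going by these compounds, whether either change truly moves inhibition beyond the scatter stays open. Also open, on these data alone, is how a methyl ester in place of the carboxylic acid would read in this assay.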